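A few compounds are considered here, and "the series" means these few. Any claim that something is new, unique, unknown or untested is made for them only; others in the source may bear on it.

Values measured in a functional assay on HeLa cells (Homo sapiens) for inhibition, read by CCK-8 assay, with a stated time of 48 h; a higher number here means a weaker inhibitor, a lower number a stronger inhibitor:

compound 1 `COc1cc(-c2ccnc3cc(-c4ccc(C)c(C)c4)nn23)cc(OC)c1OC` gives 241 nM
compound 2 `COc1cc(-c2ccnc3cc(-c4ccc(N(C)C)cc4)nn23)cc(OC)c1OC` gives 378 nM
compound 3 `COc1cc(-c2ccnc3cc(-c4cccc(C)c4)nn23)cc(OC)c1OC` gives 4230 nM

Compound 3 stands highest of the three in this assay and is the weakest inhibitor of the set. The other two lie close together, with a 1.6-fold higher number from compound 1 to compound 2 (0.20 log units; within the scatter). Compound 4 `COc1cc(-c2ccnc3cc(-c4ccc5cnn(C)c5c4)nn23)cc(OC)c1OC` has not yet been measured. It keeps the shared core and changes one group, with 1-methyl-1H-indazol-6-yl in place of 3-methylphenyl on an aromatic carbon.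

Among the compounds with values here, two measured steps bear on this change, and both are large. One is an 18-fold higher number from compound 1 to compound 3 (1.24 log units; beyond the scatter), where only a methyl is lost. The other is an 11-fold higher number from compound 2 to compound 3 (1.05 log units; beyond the scatter), where 3-methylphenyl again replaces another group. In both, the compound carrying 3-methylphenyl has the higher number. Neither compound 1 nor compound 2 carries an indazolyl group, so the data do not test this group directly. A sizeable move toward a lower number in this assay is therefore expected, though probably not the full size of those two steps, and with wide uncertainty. The expected change is a 7.1-fold lower number from compound 3 to compound 4 (0.85 log units; beyond the scatter). For compound 4 the estimated value is 600 nM, with an expected range from 120 nM to 3000 nM.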

Compound 4, half-maximal inhibitory concentration: 97 nM
For compound 4 the middle estimate is 6.2-fold (0.79 log units) above the measured one; measured number outside the range, below it.
By their numbers in this assay, from the lowest: compound 4; then compounds 1 and 2 (each within the scatter of the next); then compound 3.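

At the aromatic carbon next to the ring nitrogen, the measured groups had all been substituted phenyl rings, and in this assay the two best of these, in compounds 1 and 2, lay within the scatter of each other. The 1-methyl-1H-indazol-6-yl group, with its five-membered aromatic ring and six-membered carbon ring, shows that this position accepts a group that is not a substituted phenyl and that the number can fall further: it recovers far more than the loss seen with 3-methylphenyl (a 44-fold lower number from compound 3 to compound 4 (1.64 log units; beyond the scatter)) and also passes both earlier phenyl compounds, by modest steps (a 3.9-fold lower number from compound 2 to compound 4 (0.59 log units; beyond the scatter); a 2.5-fold lower number from compound 1 to compound 4 (0.40 log units; beyond the scatter)), making compound 4 the strongest inhibitor of the four. No measurement available here accounts for this gain.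

The compounds shown do not separate the contribution of the methyl on the indazole nitrogen from that of the ring itself, as an unmethylated 1H-indazol-6-yl group would. They also leave open whether the gain is particular to this attachment of the indazole or extends to other two-ring groups such as a benzimidazole or a quinoline.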